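Changing the amide aryl group in a paw-edema series

The compounds below may be only part of what the source reports. "The series", "measured", "known", "first", "only" and "open" are said of these compounds alone.

Measured compounds:
compound 1 `COc1cc2c(cc1OC)C(CC(=O)Nc1ccccc1)CC2`: 30%
compound 2 `COc1cc2c(cc1OC)C(CC(=O)Nc1cccc(Cl)c1)CC2`: 63.3%
compound 3 `COc1cc2c(cc1OC)C(CC(=O)Nc1ccc(C)cc1)CC2`: 30%

All three share one core and were tested in a functional assay on the whole organism (strain Wistar) for inhibition, with Rattus norvegicus as the target, read by paw edema, with a stated time of 24 h, at a dose of 100 mg/kg; on this read-out lower numbers stand for less inhibition and higher numbers for more inhibition at the one dose given (going by the name of the read-out). Compound 3 stands level with compound 1, the two together lowest of the three, while compound 2 sits clearly higher, as a number 33.3 percentage points lower from compound 2 to compound 3 (beyond the scatter) shows. Compound 4 `COc1ccccc1NC(=O)CC1CCc2cc(OC)c(OC)cc21` differs from compound 3 in one place: 2-methoxyphenyl in place of 4-methylphenyl on an amide-type nitrogen. Within the data shown here, two measured steps touch the ring on the amide-type nitrogen: a number 33.3 percentage points higher from compound 1 to compound 2 (beyond the scatter), and no change at the digits printed from compound 1 to compound 3 (within the scatter). Among the measured compounds shown here, no measured step places a methoxy on that ring, so the change has no direct precedent. A step within the scatter is therefore expected, a number 5 percentage points higher from compound 3 to compound 4 (within the scatter). Compound 4 is expected to give 35%, somewhere between 20% and 55%.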

Compound 4, a percentage reported as inhibition, in the whole organism at one dose (the size of the read-out at that dose, not a potency): 30%
The estimate for compound 4 lay 5 percentage points above the measured number; the measured number falls inside the stated range.
By their numbers in this assay, from the lowest: compounds 1, 3 and 4 (each within the scatter of the next); then compound 2.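

In this assay, a methoxy on the ring on the amide-type nitrogen behaves like the methyl: 2-methoxyphenyl gives no change at the digits printed from compound 3 to compound 4 (within the scatter) in place of 4-methylphenyl, and methoxy gives no change at the digits printed from compound 1 to compound 4 (within the scatter) in place of hydrogen. The 3-chlorophenyl compound alone stands apart, with a number 33.3 percentage points lower from compound 2 to compound 4 (beyond the scatter) when 2-methoxyphenyl replaces it. Nothing available explains this difference.

As far as these compounds go, it remains open whether the higher number follows the chloro group itself or its place on the ring. How an amine or a carboxylic acid on this ring would read is also unknown.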